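Swapping (3-aminobenzyl)oxy for 1H-1,2,4-triazol-1-yl

The source may report more compounds than this note shows. Statements on the series, on what has been measured and on what is new or still open speak of the compounds shown alone.

Measured in a functional assay on SK-OV-3 cells (Homo sapiens) for inhibition, read by CCK-8 assay, with a stated time of 70 h; a lower number here means a stronger inhibitor, a higher number a weaker inhibitor:
- compound 1 `COc1ccc(OCCOCCNC2CCCC2)cc1`: 99100 nM
- compound 2 `Clc1ccc(COc2ccc(OCCOCCNC3CCCC3)cc2)cc1`: 7670 nM
- compound 3 `Nc1cccc(COc2ccc(OCCOCCNC3CCCC3)cc2)c1`: 10800 nM

Compound 3 gives 10800 nM, and the data show a 1.4-fold higher number from compound 2 to compound 3 (0.15 log units; within the scatter), so these two values cannot be told apart. The gap to the remaining measured compound is clear: a 9.2-fold lower number from compound 1 to compound 3 (0.96 log units; beyond the scatter).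

Compound 4 `c1ncn(-c2ccc(OCCOCCNC3CCCC3)cc2)n1` is the next structure, and the change is 1H-1,2,4-triazol-1-yl in place of (3-aminobenzyl)oxy on an aromatic carbon. It sits on an aromatic carbon of the six-membered aromatic ring of carbon only, para to a large group. Among the measured compounds shown here, two measured steps bear on it: a 13-fold lower number from compound 1 to compound 2 (1.11 log units; beyond the scatter) and a 9.2-fold lower number from compound 1 to compound 3 (0.96 log units; beyond the scatter). Both came with a 4-chlorophenyl or 3-aminophenyl group on the saturated chain carbon, and compound 4 carries neither. For the measured compounds named here, no measured compound carries 1H-1,2,4-triazol-1-yl, so the data offer only an indirect guide. A moderate rise is expected in this assay, giving back much of the drop seen in a 9.2-fold lower number from compound 1 to compound 3 (0.96 log units; beyond the scatter). The expected step is a 4.2-fold higher number from compound 3 to compound 4 (0.62 log units; beyond the scatter). For compound 4 the estimate is 45000 nM, with an expected range from 14000 nM to 120000 nM.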

Compound 4, half-maximal inhibitory concentration: > 100000 nM
Compound 4: only a limit was reported; the forecaster's own chance of this, stated with the estimate: 15%; middle value at least 2.2-fold (0.34 log units) from the limit.
By their numbers in this assay, from the lowest: compounds 2 and 3 (each within the scatter of the next); then compound 1. At a limit, above all of these: compound 4.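

In this assay compound 4 reached only a limit of the assay: the limit of > 100000 nM in this assay, at which 1 of the 4 values shown sits.
The aromatic carbon para to a large group proved sensitive to what it carries, with an at least 9.2-fold higher number from compound 3 to compound 4 (0.96 log units; beyond the scatter) and an at least 13-fold higher number from compound 2 to compound 4 (1.11 log units; beyond the scatter) once 1H-1,2,4-triazol-1-yl stood in place of the (3-aminobenzyl)oxy and (4-chlorobenzyl)oxy groups, so this five-membered aromatic ring did not stand in for either of them. Against methoxy the data give a number no lower from compound 1 to compound 4 (the limit leaves the size open), a step whose size cannot be read, which leaves 1H-1,2,4-triazol-1-yl unplaced against methoxy.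

The compounds shown do not separate the triazole ring itself from the loss of the benzyloxy arm. A directly attached phenyl group, or a triazole carried on a methyleneoxy link, would bear on that question.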